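The compounds below may be only part of what the source reports. "The series", "measured", "known", "first", "only" and "open" are said of these compounds alone.

In a functional assay on HT-29 cells (Homo sapiens) for antiproliferative activity, read by MTT assay, with a stated time of 72 h (on this read-out higher numbers stand for weaker inhibition and lower numbers for stronger inhibition), the measured compounds stand as follows:

compound 1, `O=C(Nc1ccc(Oc2ccnc3[nH]ccc23)cc1)c1cc2cccnc2n(-c2ccc(F)cc2)c1=O`: 160 nM
compound 2, `O=C(Nc1ccc(Oc2ccnc3[nH]ccc23)cc1)c1cc2cccnc2n(-c2ccc(Cl)cc2)c1=O`: 280 nM
compound 3, `Cn1ccc2c(Oc3ccc(NC(=O)c4cc5cccnc5n(-c5ccc(F)cc5)c4=O)cc3F)ccnc21`: 160 nM

Compound 2 differs from compound 1 by chloro in place of fluoro on an aromatic carbon, and that change gave a 1.8-fold higher number from compound 1 to compound 2 (0.24 log units; within the scatter). Compound 3 rests on a different core; how its core differs from that of compound 1 is not broken down here. Its value is level with compound 1 and within the scatter of compound 2.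

Compound 4, `Cn1ccc2c(Oc3ccc(NC(=O)c4cc5cccnc5n(-c5ccc(Cl)cc5)c4=O)cc3F)ccnc21`, has not been measured. Among the measured compounds shown here, it differs from compound 3 by chloro in place of fluoro on an aromatic carbon, the same change, at the same place, as the one between compound 1 and compound 2. That earlier change gave a 1.8-fold higher number from compound 1 to compound 2 (0.24 log units; within the scatter). The step to compound 4 is therefore expected to be about as small, and to start from compound 3 because compound 3 gives 160 nM in this assay. Compound 4 is estimated at 260 nM, with a likely span from 130 nM to 520 nM, which means an expected step of a 1.6-fold higher number from compound 3 to compound 4 (0.21 log units; within the scatter).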

Compound 4, half-maximal inhibitory concentration: 220 nM
Beside the measured number, compound 4's estimate is 1.2-fold (0.07 log units) above it; low and high end bracket the measured number.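

In this assay, putting 4-chlorophenyl in place of 4-fluorophenyl gave a 1.4-fold higher number from compound 3 to compound 4 (0.14 log units; within the scatter), so on this second core the change again stays small. Set side by side, the two steps cannot be told apart: the same change on two cores in this assay, a 1.8-fold higher number (0.24 log units; within the scatter) from compound 1 to compound 2 and a 1.4-fold higher number (0.14 log units; within the scatter) from compound 3 to compound 4, 1.3-fold (0.10 log units) apart, within the scatter of two such steps

Each step lies within the scatter, so this shows that the change carried over between these two cores without a visible difference, but it does not show that chloro truly differs from fluoro, and two cores cannot speak for any others.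

The compounds shown carry only fluoro or chloro at this place. Going by these compounds, whether a methoxy group, an amine or a carboxylic acid there would move the number further remains open.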